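A few compounds are considered here, and "the series" means these few. Any claim that something is new, unique, unknown or untested is made for them only; others in the source may bear on it.

Among the compounds with values here, in an in vitro functional assay on HEK ts201 cells for antagonist activity at Neuronal acetylcholine receptor; alpha4/beta2 (Homo sapiens), read by fluorescence and calcium flux (a lower number here means a stronger inhibitor, a higher number a weaker inhibitor), compound 1 `[N-]=[N+]=NCCCN1CCCC(COC(=O)c2ccccc2-c2ccccc2)C1` gives 4270 nM, the lowest of the three numbers measured so far. Compound 2 `O=C(OCC1CCCN(CCCCCOc2ccc(Cl)cc2)C1)c1ccccc1-c1ccccc1` gives 14500 nM, and compound 3 `COc1ccc(OCCCCCN2CCCC(COC(=O)c3ccccc3-c3ccccc3)C2)cc1` gives 14500 nM. Both of the steps that start from compound 1 swap its azido group for a phenoxy-bearing group at the end of the same chain, and both weaken inhibition: a 3.4-fold higher number from compound 1 to compound 2 (0.53 log units; beyond the scatter) and a 3.4-fold higher number from compound 1 to compound 3 (0.53 log units; beyond the scatter). Between the two phenoxy compounds, no change at the digits printed from compound 2 to compound 3 (within the scatter).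

Compound 4 `CN1CCCC(COC(=O)c2ccccc2-c2ccccc2)C1` differs from compound 1 in another way: hydrogen in place of 2-azidoethyl on a saturated chain carbon bound to an amine nitrogen in a ring. Instead of changing the end of the chain, this removes most of it, leaving a methyl on the ring nitrogen. Within the data shown here, no measured step does this, so the two steps from compound 1 bear on it only indirectly, showing that altering the chain shifts the number by a modest amount. A modest step is therefore expected, a 1.6-fold higher number from compound 1 to compound 4 (0.21 log units; within the scatter), most likely toward weaker inhibition because compound 1 gives 4270 nM as the best number while keeping its full chain. Compound 4 is estimated at 7000 nM, within a range of 2000 nM to 25000 nM.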

Compound 4, half-maximal inhibitory concentration: 6920 nM
Compound 4: the middle estimate sits 1.0-fold (0.00 log units) above what was measured; low and high end bracket the measured number.
By their numbers in this assay, from the lowest: compounds 1 and 4 (each within the scatter of the next); then compounds 2 and 3 (each within the scatter of the next).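

In this assay, the change from 3-azidopropyl to methyl on the amine nitrogen in the ring gives a 1.6-fold higher number from compound 1 to compound 4 (0.21 log units; within the scatter). The earlier compounds shown here showed only swaps at the far end of a chain, whereas this step removes most of the chain and the two numbers still cannot be told apart, so the azido-ended chain is not needed to reach this level of inhibition. No measurement here bears on what lies behind this result.

Left open is whether the higher numbers of compound 2 and compound 3 follow from chain length or from the phenoxy end, which a plain pentyl chain on the same nitrogen would help separate. Also open, going by these compounds, is how a bare amine hydrogen in place of the methyl, or a carboxylic acid at the chain end, would read.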